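Menthyl-to-decyl swap on the ether oxygen of compound 1

The source may report more compounds than this note shows. Statements on the series, on what has been measured and on what is new or still open speak of the compounds shown alone.

Compound 1 `C=CCc1cc(OC)c(OC(C)C(O[C@@H]2C[C@H](C)CC[C@H]2C(C)C)c2ccc(O)c(OC)c2)c(OC)c1` gives 28 nM in an assay on HEK293 cells for agonist activity at transient receptor potential cation channel subfamily M member 8 (Homo sapiens), read by fluorescence and calcium flux, with a stated time of 5 min (on this read-out lower numbers stand for an effect already at smaller amounts and higher numbers for an effect only at larger amounts of compound), the lowest of the two numbers recorded in this series. Among the measured compounds shown here, compound 3 `C=CCc1cc(OC)c(OC(C)C(OCCOCCCC)c2ccc(O)c(OC)c2)c(OC)c1` gives 153 nM; the step of a 5.5-fold higher number from compound 1 to compound 3 (0.74 log units; beyond the scatter) is the only single-place change measured so far. For the measured compounds named here, compound 2 `C=CCc1cc(OC)c(O[C@H](C)[C@@H](O)c2ccc(OC)c(OC)c2)c(OC)c1` reaches only the limit > 10000 nM in this assay, a limit and not a number (the limit of > 10000 nM in this assay, at which 1 of the 3 values shown sits), and as it differs from compound 1 in more than one place no step to it is drawn.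

Compound 4 `C=CCc1cc(OC)c(OC(C)C(OCCCCCCCCCC)c2ccc(O)c(OC)c2)c(OC)c1` differs from compound 1 at the same oxygen as compound 3: decyl in place of 2-isopropyl-5-methylcyclohexyl on an oxygen on a saturated carbon. Going by the values given here, the step from compound 1 to compound 3 is the one measured step that bears on this change, and it showed a modest loss when the ring gave way to an open chain. Decyl is another open chain, of the same heavy-atom count as the group it replaces, so a loss of similar size is expected rather than none, with the direction towards higher numbers.

Compound 4 is therefore expected to give 120 nM in this assay, within 40 nM to 400 nM. The estimated step of a 4.3-fold higher number from compound 1 to compound 4 (0.63 log units; beyond the scatter) is taken as comparable in size to the measured step to compound 3.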

Compound 4, half-maximal effective concentration: 66 nM
For compound 4 the middle estimate is 1.8-fold (0.26 log units) above the measured one; the range from low to high includes it.
By their numbers in this assay, from the lowest: compound 1; then compound 4; then compound 3. At a limit, above all of these: compound 2.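

Decyl in place of 2-isopropyl-5-methylcyclohexyl on this oxygen gives a 2.4-fold higher number from compound 1 to compound 4 (0.37 log units; beyond the scatter) in this assay and so keeps the number in the same range as the ring, which shows that an open chain of the same carbon count can largely stand in for it, although the loss remains beyond the scatter. The two open chains also differ from each other: octyl in place of butoxy on a saturated chain carbon, two bonds along the chain from an oxygen on a saturated carbon, gives a 2.3-fold lower number from compound 3 to compound 4 (0.37 log units; beyond the scatter) and shows that the make-up of the chain moves the number as well as the presence or absence of the ring. No measurement given here accounts for either step.

Still open, from the compounds shown here alone, is how the number follows chain length and chain end at this oxygen, which a longer chain such as dodecyl, a shorter one such as hexyl, or a decyl chain ending in an amine or a carboxylic acid would test. Also open, going by these compounds, is how much of the small edge of compound 1 belongs to the ring itself and how much to its substituents and defined stereocentres, a question that a plain cyclohexyl group on the same oxygen would address.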